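This account rests on a few compounds, and the source may have more. Where it says the series, first, only, none or still open, it means among the compounds named here.

Of the compounds shown here, three built on one shared core have been measured in a functional assay on BXPC-3 cells (Homo sapiens) for antiproliferative activity, read by MTT assay, with a stated time of 24 h; on this read-out lower numbers stand for stronger inhibition and higher numbers for weaker inhibition. Compound 1 `CCn1c(C(=O)N[C@@H](C)C(=O)OC)ccc1C(CC)(CC)c1ccc(OCS(=O)(=O)c2ccccc2)c(C)c1` gives 17900 nM. Compound 3 `CCn1c(C(=O)NC(C)(C)CO)ccc1C(CC)(CC)c1ccc(OCS(=O)(=O)c2ccccc2)c(C)c1` gives 18300 nM, and the step of a 1.0-fold higher number from compound 1 to compound 3 (0.01 log units; within the scatter) stays within the scatter. For compound 2 `CCn1c(C(=O)NCCNC(=O)OC(C)(C)C)ccc1C(CC)(CC)c1ccc(OCS(=O)(=O)c2ccccc2)c(C)c1` the assay reports only a limit, > 50000 nM. Compound 2 therefore stands at the weak end of the numbers shown: an at least 2.7-fold higher number from compound 1 to compound 2 (0.44 log units; beyond the scatter) and an at least 2.7-fold lower number from compound 2 to compound 3 (0.43 log units; beyond the scatter).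

Compound 4 `CCn1c(C(=O)N[C@@H](CC(=O)O)C(=O)O)ccc1C(CC)(CC)c1ccc(OCS(=O)(=O)c2ccccc2)c(C)c1` has not been measured. It differs from compound 2 by 1,2-dicarboxyethyl in place of 2-((tert-butoxycarbonyl)amino)ethyl on an amide-type nitrogen. Among the compounds with values here, the steps that bear on this change are the two that exchange the group on the amide-type nitrogen of compound 2, an at least 2.7-fold higher number from compound 1 to compound 2 (0.44 log units; beyond the scatter) and an at least 2.7-fold lower number from compound 2 to compound 3 (0.43 log units; beyond the scatter); each moved the number at least modestly, and in each the one with the 2-((tert-butoxycarbonyl)amino)ethyl group sits at the limit (the limit of > 50000 nM in this assay, at which 1 of the 3 values shown sits). The 1,2-dicarboxyethyl group is not represented among the measured compounds, so the direction rests on those two steps alone.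

The writer expects compound 4 to land near or somewhat below compound 2, a step of an at least 1.4-fold lower number from compound 2 to compound 4 (0.15 log units; that floor lies within the scatter). The estimate for compound 4 in this assay is 35000 nM, within a range from 12000 nM to 100000 nM.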

Compound 4, half-maximal inhibitory concentration: > 50000 nM
Compound 4 was reported as a limit (the forecaster's own chance of this, stated with the estimate: 55%); middle value at least 1.4-fold (0.15 log units) away from the limit.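

Compound 4, with 1,2-dicarboxyethyl on the amide-type nitrogen, gives like compound 2 only a limit and not a number in this assay: the limit of > 50000 nM in this assay, at which 2 of the 4 values shown sit. Measured against the two compounds that do carry numbers, this group shifts the read-out towards weaker inhibition, with an at least 2.7-fold higher number from compound 3 to compound 4 (0.43 log units; beyond the scatter) and an at least 2.7-fold higher number from compound 1 to compound 4 (0.44 log units; beyond the scatter). The step between compound 2 and compound 4 cannot be read, so the position now holds two quite different groups at the limit, while only 1-(methoxycarbonyl)ethyl and 1-(hydroxymethyl)-1-methylethyl give numbers.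

From the compounds shown here alone, how far compound 2 and compound 4 lie beyond the limit stays open. Also open, going by these compounds, is whether a single carboxylic acid such as 1-carboxyethyl, or the dimethyl ester of the 1,2-dicarboxyethyl group, would return to a measurable number.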